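Working notes: extending the chain from compound 2 to compound 4

The source may report more compounds than this note shows. Statements on the series, on what has been measured and on what is new or still open speak of the compounds shown alone.

- compound 1 `COc1ccc(N(C)c2nc(C)nc3ccccc23)cc1C(=O)OCC[Se]C#N` gives 890 nM
- compound 2 `COc1ccc(N(C)c2nc(C)nc3ccccc23)cc1C(=O)OCCCC[Se]C#N` gives 975 nM
- compound 3 `COc1ccc(N(C)c2nc(C)nc3ccccc23)cc1[Se]C#N` gives 59 nM

In a functional assay on HepG2 cells (Homo sapiens) for inhibition, read by MTT assay, with a stated time of 48 h (a higher number here means a weaker inhibitor, a lower number a stronger inhibitor), compound 2 sits with compound 1 at the high end of the three numbers, and the gap to compound 3 is large: a 17-fold lower number from compound 2 to compound 3 (1.22 log units; beyond the scatter) in this series.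

Compound 4 `COc1ccc(N(C)c2nc(C)nc3ccccc23)cc1C(=O)OCCCCC[Se]C#N` has not yet been measured. Its change from compound 2 is a group of 4 heavy atoms (2 carbon, 1 nitrogen, 1 selenium; no ring) in place of a group of 3 heavy atoms (1 carbon, 1 nitrogen, 1 selenium; no ring), on a saturated chain carbon, four bonds along the chain from an oxygen next to a carbonyl group and nothing else.

Among the measured compounds shown here, one measured step bears directly on this: a 1.1-fold higher number from compound 1 to compound 2 (0.04 log units; within the scatter) is also a lengthening of the same chain, and it is small. A single step sets no trend. For the measured compounds named here, the step of a 15-fold lower number from compound 1 to compound 3 (1.18 log units; beyond the scatter) is large, as is the one to compound 3 from compound 2, but both remove the whole chain from the aromatic carbon and so say little here.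

No step beyond the scatter is expected in this assay and the estimated change is a 1.0-fold higher number from compound 2 to compound 4 (0.01 log units; within the scatter) for this extension. For compound 4 the estimate is 1000 nM within an expected range of 550 nM to 1800 nM until a measurement is available.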

Compound 4, half-maximal inhibitory concentration: 667 nM
For compound 4 the middle estimate is 1.5-fold (0.18 log units) above the measured one; the range from low to high includes it.
By their numbers in this assay, from the lowest: compound 3; then compounds 4, 1 and 2 (each within the scatter of the next).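

In this assay the further lengthening of the chain gives a 1.5-fold lower number from compound 2 to compound 4 (0.16 log units; within the scatter) and the widest span of chain lengths shown gives a 1.3-fold lower number from compound 1 to compound 4 (0.13 log units; within the scatter). With both steps added to the earlier one, compound 1, compound 2 and compound 4 all lie within the scatter of each other, so the chain length at this position makes no readable difference across these three compounds, while compound 3, which lacks the chain, stays apart from them. Nothing shown gives a reason for this lack of response to chain length.

Going by these compounds, whether a longer chain than that of compound 4 would stay within the same scatter remains open. So does whether an amide in place of the ester, or an amine at the chain end, would bring the number closer to that of compound 3.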